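Two anilinoquinoxalines and a benzamide: expecting a third

This account rests on a few compounds, and the source may have more. Where it says the series, first, only, none or still open, it means among the compounds named here.

Measured so far:
Compound 1 `Cc1cccc(Nc2nc3ccccc3nc2Nc2cccc(C)c2C)c1C`, 24800 nM
Compound 2 `O=C(Nc1nc2ccccc2nc1Nc1ccc(F)cc1)c1ccccc1`, 19700 nM

Both numbers come from a functional assay on PC-3 cells (Homo sapiens) for cytotoxicity, with a stated time of 72 h; a higher number here means a weaker inhibitor, a lower number a stronger inhibitor. In this assay compound 2 gives 19700 nM and compound 1 gives 24800 nM; the two numbers sit within the usual scatter of each other, so neither compound can be called the stronger. Compound 3 `Fc1ccc(Nc2nc3ccccc3nc2Nc2ccc(F)cc2)cc1` has not yet been measured. It differs from compound 2 in one place: 4-fluorophenyl in place of benzoyl on a nitrogen on an aromatic ring. The result is a compound carrying the same (4-fluorophenyl)amino group twice, on both nitrogens attached to the shared core, much as compound 1 carries the same substituted anilino group twice. Among the compounds with values here, no measured pair shows this exact change, so the expectation rests on compound 1 and compound 2 alone: since compound 1 gives 24800 nM and compound 2 gives 19700 nM, no shift beyond the scatter is expected, and the estimated step is a 1.0-fold higher number from compound 2 to compound 3 (0.01 log units; within the scatter). For compound 3 the expected value in this assay is 20000 nM, within a range from 7000 nM to 60000 nM.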

Compound 3, half-maximal inhibitory concentration: 4800 nM
For compound 3 the middle estimate is 4.2-fold (0.62 log units) above the measured one; measured number outside the range, below it.
By their numbers in this assay, from the lowest: compound 3; then compounds 2 and 1 (each within the scatter of the next).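

In this assay the change of 4-fluorophenyl in place of benzoyl brings a 4.1-fold lower number from compound 2 to compound 3 (0.61 log units; beyond the scatter) at this position, a modest step. Within the data shown here, it is the first step and the first sign that the group on a nitrogen on an aromatic ring can shift the number, here with benzamido replaced by (4-fluorophenyl)amino. Nothing at hand explains why the number falls with this change.

The compounds shown leave open whether the fluorine contributes to the step or whether any aromatic ring attached directly to this nitrogen would serve as well, a question that a plain phenyl group there could address. They also leave open how a non-aromatic group at the same place, such as a cyclohexyl ring or a short alkyl chain, would compare.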